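This account rests on a few compounds, and the source may have more. Where it says the series, first, only, none or still open, it means among the compounds named here.

Working notes on the series. In an ADME assay on MT2 cells (Homo sapiens) for cytotoxicity, read by XTT assay, with a stated time of 4 days (on this read-out lower numbers stand for higher toxicity in this test and higher numbers for lower toxicity in this test), compound 1 `Cc1ccc(-c2c3c(nc(C)c2C(OC(C)(C)C)C(=O)O)CCN(c2cccc(-c4ccccc4)c2)C3)cc1` gives > 40000 nM, which is a limit of the assay and not a number. Compound 2 `Cc1ccc(-c2c3c(nc(C)c2C(OC(C)(C)C)C(=O)O)CCN(CCCC2CCCC2)C3)cc1` gives > 40000 nM in this assay, again a limit rather than a number. Compound 3 `Cc1ccc(-c2c3c(nc(C)c2C(OC(C)(C)C)C(=O)O)CCN(Cc2ccccc2-c2ccccc2)C3)cc1` stands at > 40000 nM in this assay, also a limit. On the numbers at hand compound 3 sits with the other two at the limit, and the two steps leading to it, a step that the two limits leave unreadable from compound 1 to compound 2 and a step that the two limits leave unreadable from compound 2 to compound 3, have no readable size because of the limit of > 40000 nM in this assay, at which 3 of the 3 values shown sit. The unmeasured compound 4 `Cc1ccc(-c2c3c(nc(C)c2C(OC(C)(C)C)C(=O)O)CCN(C)C3)cc1` differs from compound 3 by hydrogen in place of 2-phenylphenyl on a saturated chain carbon bound to an amine nitrogen in a ring. Neither measured step bears on this change in a readable way, since neither returned a number. Compound 4 is therefore expected to sit at the limit as well, the step of a number no higher from compound 3 to compound 4 (the limit leaves the size open) being expected to be none beyond the scatter. For compound 4 the estimate in this assay is 40000 nM, between 20000 nM and 100000 nM, most likely reported only as a limit.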

Compound 4, half-maximal cytotoxic concentration: > 40000 nM
Compound 4: no number, only a limit (the forecaster's own chance of this, stated with the estimate: 85%); the middle value lies on the limit itself.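

Compound 4 gives > 40000 nM in this assay, a limit and not a number. No step linking compound 4 to compound 1, compound 2 or compound 3 can be read, because of this: the limit of > 40000 nM in this assay, at which 4 of the 4 values shown sit.

The compounds shown leave open whether any group on the amine nitrogen in a ring changes the read-out in this assay.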